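This account rests on a few compounds, and the source may have more. Where it says the series, first, only, none or still open, it means among the compounds named here.

Compounds 1 to 3 share one core and differ only in the carbamate chain: compound 1 `COC(=O)N1CCC(Oc2ncnc3c2CCN3c2ccc(S(C)(=O)=O)cc2F)CC1` gives 119% in a functional assay on CHO-K1 cells with Glucose-dependent insulinotropic receptor (Homo sapiens) as the target, read by a luciferase reporter, with a stated time of 5 h (on this read-out lower numbers stand for smaller maximal responses and higher numbers for larger maximal responses), compound 2 `CCCCOC(=O)N1CCC(Oc2ncnc3c2CCN3c2ccc(S(C)(=O)=O)cc2F)CC1` gives 131%, and compound 3 `CC(C)(C)COC(=O)N1CCC(Oc2ncnc3c2CCN3c2ccc(S(C)(=O)=O)cc2F)CC1` gives 80%, the lowest of the three. The steps were a number 12 percentage points higher from compound 1 to compound 2 (beyond the scatter), a number 39 percentage points lower from compound 1 to compound 3 (beyond the scatter) and a number 51 percentage points lower from compound 2 to compound 3 (beyond the scatter). Compound 4 `CCS(=O)(=O)N1CCC(Oc2ncnc3c2CCN3c2ccc(S(C)(=O)=O)cc2F)CC1` carries ethylsulfonyl in place of neopentyloxycarbonyl on an amine nitrogen in a ring. Going by the values given here, no measured step touches a sulfonyl; the three steps only show that lengthening or branching the chain on the saturated carbon bound to the oxygen moves the maximal response over a wide span. Compound 4 is therefore expected to give 105%, between 65% and 140%, an estimated step of a number 25 percentage points higher from compound 3 to compound 4 (beyond the scatter) upward, with low confidence.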

Compound 4, largest response reached (reported as percent of maximum), in percent of the reference or control that the assay uses: 51%
Beside the measured number, compound 4's estimate is 54 percentage points above it; the whole stated range lies above it.
By their numbers in this assay, from the lowest: compound 4; then compound 3; then compound 1; then compound 2.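

Ethylsulfonyl on the amine nitrogen in a ring gives the lowest maximal response of the four compounds, with a number 29 percentage points lower from compound 3 to compound 4 (beyond the scatter) and a number 68 percentage points lower from compound 1 to compound 4 (beyond the scatter) and also a number 80 percentage points lower from compound 2 to compound 4 (beyond the scatter) in this series. The earlier compounds shown here varied only the chain on the oxycarbonyl group, whereas here the group bound directly to the nitrogen changes, and the response falls in all three comparisons. Nothing available explains this fall.

From the compounds shown here alone, whether it belongs to the sulfonyl itself or to its ethyl chain stays open. Methylsulfonyl or butylsulfonyl on the same nitrogen, or an amide there, would separate the two.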